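Notes on a dihydropyridine series: step from compound 2 to 3

A few compounds are considered here, and "the series" means these few. Any claim that something is new, unique, unknown or untested is made for them only; others in the source may bear on it.

Measured so far:
Compound 1 `CCOC(=O)C1=C(N/C=N/c2ncc(-c3ccccc3)s2)Nc2[nH]nc(C)c2C1c1ccc(N(C)C)cc1` — 9790 nM
Compound 2 `CCOC(=O)C1=C(N/C=N/c2ccc([N+](=O)[O-])cc2)Nc2[nH]nc(C)c2C1c1ccc(N(C)C)cc1` — 50900 nM

Going by the values given here, compound 2 gives the highest number of the two in a functional assay on HepG2 cells (Homo sapiens) for inhibition, read by MTT assay, with a stated time of 48 h; on this read-out lower numbers stand for stronger inhibition and higher numbers for weaker inhibition; the only measured step, a 5.2-fold higher number from compound 1 to compound 2 (0.72 log units; beyond the scatter), is the sole point of comparison. Compound 3 `CCOC(=O)C(=NNC1=C(C(=O)OCC)C(c2ccc(N(C)C)cc2)c2c(C)n[nH]c2N1)C(=O)OCC` differs from compound 2 by a group of 12 heavy atoms (7 carbon, 1 nitrogen, 4 oxygen; no ring) in place of a group of 11 heavy atoms (7 carbon, 2 nitrogen, 2 oxygen; one six-membered aromatic ring of carbon only), on an amine nitrogen. That step replaced one ring with another on a double-bonded nitrogen, whereas here the ring is removed altogether, so it bears only loosely on the present change. Among the compounds with values here, no step of this kind is available, and no direction is expected beyond the scatter; compound 3 is estimated at 40000 nM (range 10000 nM to 150000 nM), i.e. an expected step of a 1.3-fold lower number from compound 2 to compound 3 (0.10 log units; within the scatter).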

Compound 3, half-maximal inhibitory concentration: 80800 nM
Estimate against measurement, compound 3: 2.0-fold (0.31 log units) below; the range from low to high includes it.
By their numbers in this assay, from the lowest: compound 1; then compounds 2 and 3 (each within the scatter of the next).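

In this assay the exchange gives a 1.6-fold higher number from compound 2 to compound 3 (0.20 log units; within the scatter), so on this amine nitrogen a group with no ring reads the same, within the scatter, as the group carrying a six-membered aromatic ring. The aromatic ring of compound 2 is therefore not required to stay at this level. Nothing on hand accounts for this result. Still open, going by these compounds, is whether a carboxylic acid or a primary amine in this place would move the number beyond the scatter. Also open, on these data alone, is whether a single methyl group would read like the larger groups.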